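From 3-chlorobenzyl to 4-chlorobenzyl at the assay limit

This account rests on a few compounds, and the source may have more. Where it says the series, first, only, none or still open, it means among the compounds named here.

In a functional assay on cells (Platelet, Homo sapiens) for inhibition (a lower number here means a stronger inhibitor, a higher number a weaker inhibitor), compound 1 (`CCOC(=O)c1ccc(-c2nn(C)c3ccccc23)cc1`) gives > 10000 nM as a limit of the assay. Compound 2 (`CCOC(=O)c1ccc(-c2nn(Cc3ccccc3Cl)c3ccccc23)cc1`) gives > 10000 nM as a limit too. Compound 3 (`CCOC(=O)c1ccc(-c2nn(Cc3cccc(Cl)c3)c3ccccc23)cc1`) gives > 10000 nM as a limit as well. Compound 3 therefore has no number of its own and stands at the limit of > 10000 nM in this assay, at which 3 of the 3 values shown sit, together with the other two.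

Compound 4 (`CCOC(=O)c1ccc(-c2nn(Cc3ccc(Cl)cc3)c3ccccc23)cc1`) differs from compound 3 by one change: 4-chlorophenyl in place of 3-chlorophenyl on a saturated chain carbon bound to an aromatic nitrogen with 4-chlorophenyl in place of 3-chlorophenyl on a saturated chain carbon bound to an aromatic nitrogen. The closest measured precedent is a step that the two limits leave unreadable from compound 2 to compound 3 as it also changes only the chlorophenyl group at this place. The other two steps, a step that the two limits leave unreadable from compound 1 to compound 2 and a step that the two limits leave unreadable from compound 1 to compound 3, add a chlorophenyl group at the same place. None of the three has a readable size, so they offer no direction and no measured size to carry over. For this change in this assay the expected outcome is a number no higher from compound 3 to compound 4 (the limit leaves the size open) with no shift beyond the scatter foreseen. Compound 4 is estimated at 10000 nM with an expected range of 3000 nM to 30000 nM and will most likely be reported only as a limit again.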

Compound 4, half-maximal inhibitory concentration: > 10000 nM
Compound 4: no number, only a limit (the forecaster's own chance of this, stated with the estimate: 75%); the middle value sits exactly at the limit.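

Compound 4 returns only a limit in this assay, so none of the steps to it from compound 1, compound 2 or compound 3 can be read: the limit of > 10000 nM in this assay, at which 4 of the 4 values shown sit.

The compounds shown leave open how strongly any of them inhibits in this assay, and whether 2-chlorophenyl, 3-chlorophenyl and 4-chlorophenyl differ at all.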